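Cytotoxicity notes on compounds 1 to 3

The source may report more compounds than this note shows. Statements on the series, on what has been measured and on what is new or still open speak of the compounds shown alone.

Measured so far:
Compound 1, `CC(=O)N1CCC(C(=O)N(CCCN2CCN(Cc3ccc(C#N)cc3)CC2)c2ccc(C)c(Cl)c2)CC1`, in an ADME assay (Homo sapiens) for cytotoxicity (on this read-out lower numbers stand for higher toxicity in this test and higher numbers for lower toxicity in this test), gives > 100000 nM, which is a limit of the assay.
Compound 2, `CC(=O)N1CCC(C(=O)N(CCCN2CCN(Cc3ccncc3)CC2)c2ccc(C)c(Cl)c2)CC1`, in this assay gives > 56700 nM, likewise a limit.

Going by the values given here, compound 2 therefore stands at a limit only, and the one further value is a limit as well (the limit of > 100000 nM in this assay, at which 1 of the 2 values shown sits, (the limit of > 56700 nM in this assay, at which 1 of the 2 values shown sits)). Compound 3, `CC(=O)N1CCC(C(=O)N(CCCN2CCN(Cc3ccc(Cl)cc3)CC2)c2ccc(C)c(Cl)c2)CC1`, differs from it by 4-chlorophenyl in place of pyridin-4-yl on a saturated chain carbon bound to an amine nitrogen in a ring. Among the compounds with values here, the single measured step, a step that the two limits leave unreadable from compound 1 to compound 2, sits between two limits and its size cannot be read, so no direction beyond the scatter is expected for a step that the limit leaves unreadable from compound 2 to compound 3. Compound 3 is expected at 90000 nM, within 40000 nM to 150000 nM, most probably again reported only as a limit.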

Compound 3, half-maximal cytotoxic concentration: 37600 nM
Estimate against measurement, compound 3: 2.4-fold (0.38 log units) above; measured number below the stated range.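

In this assay, going by these compounds alone, compound 3 is the first of the three to give a number and not a limit, so the group on a saturated chain carbon bound to an amine nitrogen in a ring can bring this read-out into measurable range. Chloro in place of cyano on an aromatic carbon gives an at least 2.6-fold lower number from compound 1 to compound 3 (0.42 log units; beyond the scatter). 4-Chlorophenyl in place of pyridin-4-yl gives an at least 1.5-fold lower number from compound 2 to compound 3 (0.17 log units; that floor lies within the scatter), so that change is not yet separated from the scatter.

As far as these compounds go, the full size of both steps stays open, and the step between the two limits cannot be read. Where a carboxylic acid or an amine in place of chloro on that aromatic carbon would fall is also open.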